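The source may hold more compounds than are shown below. What is called first, only, known or untested is meant among the compounds shown, and "the series" means these compounds.

Within the data shown here, compound 1 `CC(/C=N/Nc1ccc([N+](=O)[O-])cc1)=N\NC(=O)c1ccc(Cl)cc1` is the only member of the series that returns a number in an ADME assay on J774 cells (Mus musculus, strain BALB/c) for cytotoxicity, read by resazurin assay, with a stated time of 72 h; on this read-out higher numbers stand for lower toxicity in this test and lower numbers for higher toxicity in this test: compound 1 gives 63900 nM. Compound 2 `CC(/C=N/Nc1ccc([N+](=O)[O-])cc1)=N\NC(=O)c1ccccc1C` carries 2-methylphenyl in place of 4-chlorophenyl on a carbonyl carbon. In this assay compound 2 reaches only > 100000 nM, a limit of the assay and not a number. The step is an at least 1.5-fold higher number from compound 1 to compound 2 (0.19 log units; that floor lies within the scatter). The other value of the pair sits at the limit of > 100000 nM in this assay, at which 1 of the 2 values shown sits. Compound 3 `CC(/C=N/Nc1ccc([N+](=O)[O-])cc1)=N\NC(=O)c1ccc(C(C)(C)C)cc1` differs from compound 1 thus: tert-butyl in place of chloro on an aromatic carbon. Chloro leaves and tert-butyl enters on an aromatic carbon of a six-membered aromatic ring of carbon only, para to a large group. Among the measured compounds shown here, the single measured step swaps the whole aryl group on the carbonyl carbon and so bears only loosely on this change, and its floor lies within the scatter. No step beyond the scatter is therefore expected in this assay; the expected step is a 1.3-fold higher number from compound 1 to compound 3 (0.10 log units; within the scatter). Compound 3 is estimated at 80000 nM, between 35000 nM and 180000 nM, with a fair chance that only a limit is reported.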

Compound 3, half-maximal cytotoxic concentration: > 100000 nM
Compound 3: only a limit was reported (the forecaster's own chance of this, stated with the estimate: 40%); middle value at least 1.2-fold (0.09 log units) away from the limit.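

Unlike the earlier step, which swapped the whole aryl group on the carbonyl carbon, this change is confined to an aromatic carbon para to a large group, and tert-butyl in place of chloro gives an at least 1.5-fold higher number from compound 1 to compound 3 (0.19 log units; that floor lies within the scatter). In this assay compound 3 gives > 100000 nM, a limit of the assay and not a number, so the step has only a floor and its true size cannot be read. Compound 1 remains the only compound with a number, and the series now gathers at one end of the range: the limit of > 100000 nM in this assay, at which 2 of the 3 values shown sit.

As far as these compounds go, whether an amine or a carboxylic acid in place of chloro at this position would return a number stays open. Also open, from the compounds shown here alone, is whether fluoro or methoxy there would give a value that can be compared with that of compound 1.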